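Acid to Acetyl: What Compound 4 May Show

The source may report more compounds than this note shows. Statements on the series, on what has been measured and on what is new or still open speak of the compounds shown alone.

Compound 1 `CC(=O)c1ccc(Nc2ccnc(SCC(=O)c3ccc(Br)cc3)n2)cc1`: 25%
Compound 2 `O=C(O)c1ccc(Nc2ccnc(SCC(=O)c3ccc(C(F)(F)F)cc3)n2)cc1`: 12%
Compound 3 `CCOC(=O)c1ccc(Nc2ccnc(SCC(=O)c3ccc(C#N)cc3)n2)cc1`: 60%

In a functional assay on PC-3 cells (Homo sapiens) for inhibition, read by sulforhodamine B assay, with a stated time of 48 h, tested at 10 uM (a higher number here means more inhibition of growth at the concentration tested, a lower number less inhibition of growth), compound 2 gives 12%, the lowest of the three numbers. Compound 1 lies above it by a margin beyond the scatter, and compound 3 lies further above, also beyond the scatter. The three measured compounds differ from one another in more than one place, so no single change can be read off from them. Compound 4 `CC(=O)c1cccc(Nc2ccnc(SCC(=O)c3ccc(C(F)(F)F)cc3)n2)c1` is compound 2 with 3-acetylphenyl in place of 4-carboxyphenyl on a nitrogen on an aromatic ring. Neither compound 1 nor compound 3 carries the carboxylic acid of compound 2; compound 1 gives 25%, and compound 3 gives 60%. On that basis the expected step is a modest rise, a number 16 percentage points higher from compound 2 to compound 4 (beyond the scatter), possibly within the scatter. Compound 4 is estimated at 28%, with a range from 10% to 50%.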

Compound 4, percent growth inhibition at one concentration: 30%
For compound 4 the middle estimate is 2 percentage points below the measured one; measured number inside the range.
By their numbers in this assay, from the lowest: compound 2; then compounds 1 and 4 (each within the scatter of the next); then compound 3.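

With the rest of the structure unchanged, 3-acetylphenyl in place of 4-carboxyphenyl on a nitrogen on an aromatic ring gives, in this assay, a number 18 percentage points higher from compound 2 to compound 4 (beyond the scatter). Among these compounds, this is the first effect at this place that can be read alone, but the change replaces the carboxylic acid with an acetyl group and also alters the name's ring number, so the step cannot be assigned to either difference by itself. Nothing available here accounts for the rise. On these data alone, what remains open is how an amide or an amine at this place would compare. The compounds shown also leave open whether the same change would give a similar step with another group in place of trifluoromethyl.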